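Chloro Added to the Phenylethenyl Arm

The source may report more compounds than this note shows. Statements on the series, on what has been measured and on what is new or still open speak of the compounds shown alone.

The measured compounds, each tested in a functional assay on HCT-116 cells (Homo sapiens) for cytotoxicity, read by MTT assay, with a stated time of 72 h; on this read-out lower numbers stand for stronger inhibition and higher numbers for weaker inhibition:
compound 1 `CN1CCN(Cc2nnc(-c3cc(S(N)(=O)=O)c(SCc4ccccc4)cc3Cl)o2)CC1`, for which compound 1 gives 75000 nM
compound 2 `NCc1nnc(-c2cc(S(N)(=O)=O)c(SCc3ccccc3)cc2Cl)o1`, for which compound 2 gives 120000 nM
compound 3 `NS(=O)(=O)c1cc(-c2nnc(/C=C/c3ccccc3)o2)c(Cl)cc1SCc1ccccc1`, for which compound 3 gives 18000 nM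

Compound 3 stands lowest of the three: the steps of a 4.2-fold lower number from compound 1 to compound 3 (0.62 log units; beyond the scatter) and a 6.7-fold lower number from compound 2 to compound 3 (0.82 log units; beyond the scatter) both lie beyond the scatter, while a 1.6-fold higher number from compound 1 to compound 2 (0.20 log units; within the scatter) lies within it. Compound 4 `NS(=O)(=O)c1cc(-c2nnc(/C=C/c3ccc(Cl)cc3)o2)c(Cl)cc1SCc1ccccc1` differs from compound 3 by chloro in place of hydrogen on an aromatic carbon. Within the data shown here, none of the measured steps touches this part of the molecule; all three swapped a different group on the shared core. Among the measured compounds shown here, no measured step therefore bears on the change, and no shift beyond the scatter is expected: the step of no change at the digits printed from compound 3 to compound 4 (within the scatter) is an estimate only. Compound 4 is expected to give 18000 nM, most likely between 6000 nM and 50000 nM.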

Compound 4, half-maximal inhibitory concentration: 12000 nM
Compound 4: middle estimate off by 1.5-fold (0.18 log units), on the high side; measured number inside the range.
By their numbers in this assay, from the lowest: compounds 4 and 3 (each within the scatter of the next); then compounds 1 and 2 (each within the scatter of the next).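

The step of a 1.5-fold lower number from compound 3 to compound 4 (0.18 log units; within the scatter) shows that in this assay this ring carbon takes a chloro without a shift beyond the scatter. The 2-(4-chlorophenyl)ethenyl arm also keeps the lead over the two other groups on the shared core, with a 10-fold lower number from compound 2 to compound 4 (1.00 log units; beyond the scatter) and a 6.3-fold lower number from compound 1 to compound 4 (0.80 log units; beyond the scatter) both lying beyond the scatter. No measurement offered here explains these numbers.

Going by these compounds, whether a methoxy group, a nitrile or a carboxylic acid at this carbon would move the number stays open, as does the effect of chloro elsewhere on this ring.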